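The compounds below may be only part of what the source reports. "The series", "measured", "known", "first", "only" and "open" are said of these compounds alone.

Compound 2 `COc1ccc(-c2cc(-c3ccc(NS(C)(=O)=O)cc3)cnc2N)cn1` and compound 1 `COc1ccc(-c2cc(-c3ccc(S(=O)(=O)N(C)C)cc3)cnc2N)cn1` share one core and differ in a single group. In an in vitro ADME assay on microsomes from liver (Homo sapiens) for metabolic stability (on this read-out lower numbers stand for slow clearance and higher numbers for fast clearance), compound 1 gives 98.8 mL.min-1.g-1. In this assay compound 2 reaches only the limit of the method, giving < 7 mL.min-1.g-1. Compound 2 therefore stands at the slow end of the numbers shown, since (the limit of < 7 mL.min-1.g-1 in this assay, at which 1 of the 2 values shown sits). The measured step reads an at least 14-fold lower number from compound 1 to compound 2 (1.14 log units; beyond the scatter). Compound 3 `COc1ccc(-c2cc(-c3ccc(-n4cccn4)cc3)cnc2N)cn1` is made from compound 2 by 1H-pyrazol-1-yl in place of methanesulfonamido on an aromatic carbon. Going by the values given here, the only measured step that bears on this change is an at least 14-fold lower number from compound 1 to compound 2 (1.14 log units; beyond the scatter), where the group in the same place was altered; it is the sole guide, and it shows how strongly that group can move the number. The step of an at least 4.2-fold higher number from compound 2 to compound 3 (0.63 log units; beyond the scatter) is expected to raise the number again, though with no measured value for compound 2 its size is uncertain. Compound 3 is therefore estimated at 30 mL.min-1.g-1, within 8 mL.min-1.g-1 to 100 mL.min-1.g-1.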

Compound 3, intrinsic clearance in microsomes: 9 mL.min-1.g-1
Compound 3: the middle estimate sits 3.3-fold (0.52 log units) above what was measured, and the stated range covers the measured number.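

In this assay, going by these compounds alone, the change from dimethylsulfamoyl to 1H-pyrazol-1-yl gives an 11-fold lower number from compound 1 to compound 3 (1.04 log units; beyond the scatter), so a low number at this place does not depend on methanesulfonamido, the only one of the three groups with a hydrogen-bond donor. Compound 2 gives only a limit, not a true number: the limit of < 7 mL.min-1.g-1 in this assay, at which 1 of the 3 values shown sits. Read against that limit, the change from methanesulfonamido to 1H-pyrazol-1-yl gives an at least 1.2-fold higher number from compound 2 to compound 3 (0.10 log units; that floor lies within the scatter), and that floor lies within the scatter, so these two compounds cannot be placed in order.

The compounds shown leave open how other groups at this place would behave, such as an amine, a carboxylic acid or a simple amide. On these data alone, what in these three groups sets the number also remains unknown.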